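Swapping a hydroxyphenyl for a thiophene on a fused core

The compounds below may be only part of what the source reports. "The series", "measured", "known", "first", "only" and "open" are said of these compounds alone.

Measured so far:
compound 1 `Cc1cc(-c2ccccc2)c2ncc(CSCCc3ccccc3)n2c1` — 33 ug/mL
compound 2 `Cc1cc(-c2ccc(O)cc2)cn2c(CSCCc3ccccc3)cnc12` — > 50 ug/mL

Of the compounds shown here, two have been tested in an ADME assay on HEL cells (Homo sapiens) for cytotoxicity, with a stated time of 3 days; on this read-out higher numbers stand for lower toxicity in this test and lower numbers for higher toxicity in this test. Compound 1 `Cc1cc(-c2ccccc2)c2ncc(CSCCc3ccccc3)n2c1` gives 33 ug/mL. Compound 2 `Cc1cc(-c2ccc(O)cc2)cn2c(CSCCc3ccccc3)cnc12` reaches only a limit of the test, > 50 ug/mL, so its true number is not known; it sits at the limit of > 50 ug/mL in this assay, at which 1 of the 2 values shown sits. Among the measured compounds shown here, no single-change comparison between measured compounds exists, so no measured step can guide the next change.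

Compound 3 `Cc1cc(-c2ccsc2)cn2c(CSCCc3ccccc3)cnc12` has not yet been tested. It differs from compound 2 in one place: thiophen-3-yl in place of 4-hydroxyphenyl on an aromatic carbon. With nothing measured for this change, the step from compound 2 is expected to be small or within the usual scatter, perhaps slightly toward higher toxicity, giving an at least 1.2-fold lower number from compound 2 to compound 3 (0.09 log units; that floor lies within the scatter). Compound 3 is therefore estimated to give 40 ug/mL, within a range of 20 ug/mL to 60 ug/mL.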

Compound 3, half-maximal cytotoxic concentration: > 50 ug/mL
Compound 3 was reported as a limit; the forecaster's own chance of this, stated with the estimate: 40%; middle value at least 1.2-fold (0.09 log units) from the limit.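

Compound 2 and compound 3 both stop at a limit of this assay, so the step between them cannot be read: the limit of > 50 ug/mL in this assay, at which 2 of the 3 values shown sit.

Going by these compounds, how far either true number lies past that limit, and whether thiophen-3-yl in place of 4-hydroxyphenyl changes the read-out at all, stays open.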